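Chain Length and Growth Inhibition in Prostate Cancer Cells

This account rests on a few compounds, and the source may have more. Where it says the series, first, only, none or still open, it means among the compounds named here.

Two hydroxamic acids were examined in a functional assay on DU-145 cells (Homo sapiens) for inhibition, read by MTT assay, with a stated time of 48 h; on this read-out lower numbers stand for stronger inhibition of growth and higher numbers for weaker inhibition of growth: compound 1 `C#CCN(C)Cc1cccc(NC(=O)CCC(=O)NO)c1` and compound 2 `C#CCN(C)Cc1ccc(NC(=O)CCCC(=O)NO)cc1`. Compound 1 reaches only the limit of this assay, at > 10000 nM. Compound 2 likewise gives only a limit in this assay, at > 10000 nM. Both values therefore sit at the limit of > 10000 nM in this assay, at which 2 of the 2 values shown sit, so compound 2 stands level with the other compound on the numbers shown, and no measured step between the two exists.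

Compound 3 `C#CCN(C)Cc1ccc(NC(=O)CCCCCC(=O)NO)cc1` differs from compound 2 by 2-(hydroxycarbamoyl)ethyl in place of hydroxycarbamoyl on a saturated chain carbon, three bonds along the chain from a carbonyl carbon. Going by the values given here, no measured pair reports the effect of such a lengthening of the chain. It is nevertheless expected that compound 3 falls below the limit, with an estimated value in this assay of 3000 nM and a range from 500 nM to 10000 nM. The expected step is an at least 3.3-fold lower number from compound 2 to compound 3 (0.52 log units; beyond the scatter), beyond the usual scatter, while a fair chance remains that compound 3 again yields only a limit.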

Compound 3, concentration for 50% growth inhibition: > 10000 nM
Compound 3: no number, only a limit; the forecaster's own chance of this, stated with the estimate: 40%; middle value at least 3.3-fold (0.52 log units) from the limit.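

Compound 3 also gives only a limit in this assay, so the step from compound 2 to compound 3 cannot be read: the limit of > 10000 nM in this assay, at which 3 of the 3 values shown sit.

The compounds shown leave open how far each lies beyond that limit, and so whether the longer chain of compound 3 changes growth inhibition at all.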